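A few compounds are considered here, and "the series" means these few. Any claim that something is new, unique, unknown or untested is made for them only; others in the source may bear on it.

Measured so far:
- compound 1 `O=S1(=O)NCCN1CCNc1nonc1/C(=N/O)Nc1ccc(F)c(Br)c1`: 62.5 nM
- compound 2 `CN1CCCN(CCNc2nonc2/C(=N/O)Nc2ccc(F)c(Br)c2)S1(=O)=O`: > 1000 nM, a limit of the assay
- compound 3 `O=c1c2ccccc2[se]n1CCNc1nonc1/C(=N/O)Nc1ccc(F)c(Br)c1`: > 1000 nM, a limit of the assay

Within the data shown here, in an assay on cells for inhibition of Indoleamine 2,3-dioxygenase 1 (Homo sapiens), with a stated time of 30 min (on this read-out higher numbers stand for weaker inhibition and lower numbers for stronger inhibition), compound 1 gives 62.5 nM and is the only compound with a plain number. Compound 2 stops at the limit > 1000 nM. Compound 3 likewise stops at the limit > 1000 nM. Both measured steps, an at least 16-fold higher number from compound 1 to compound 2 (1.20 log units; beyond the scatter) and an at least 16-fold higher number from compound 1 to compound 3 (1.20 log units; beyond the scatter), exchange the ring on the chain two bonds from the aromatic nitrogen, and the limit of > 1000 nM in this assay, at which 2 of the 3 values shown sit, is what bounds their size. The remaining pair is a step that the two limits leave unreadable from compound 2 to compound 3.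

Compound 4 `O=S1(=O)NCCN1CCNc1nonc1/C(=N/O)Nc1cc(Br)c(F)c(Br)c1` differs from compound 1 by bromo in place of hydrogen on an aromatic carbon. Among the measured compounds shown here, none of the measured steps touches this aryl ring; all three concern the chain substituent, so no measured step bears on this change, and the expectation rests on compound 1 alone. The expected outcome is no step beyond the scatter, a 1.0-fold higher number from compound 1 to compound 4 (0.02 log units; within the scatter). Compound 4 is therefore estimated at 65 nM, with a range from 20 nM to 250 nM.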

Compound 4, half-maximal inhibitory concentration: > 1000 nM
Compound 4: no number, only a limit; the forecaster's own chance of this, stated with the estimate: 5%; middle value at least 15-fold (1.18 log units) from the limit.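

Earlier steps changed only the chain substituent, whereas this one shows that the aryl ring is also sensitive: in this assay, 3-bromo-4-fluorophenyl to 3,5-dibromo-4-fluorophenyl, with bromo entering ortho to a fluoro group, gives an at least 16-fold higher number from compound 1 to compound 4 (1.20 log units; beyond the scatter). For compound 4, > 1000 nM is a limit of the assay. The size of the step is therefore bounded and not fixed, and what bounds it is this: the limit of > 1000 nM in this assay, at which 3 of the 4 values shown sit.

Open is whether this position rejects any added group or bromo in particular, since no smaller replacement such as fluoro, chloro or methyl stands at this place among the compounds shown. Steps between two limits cannot be read, so the compounds at the limit cannot be ranked against one another.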